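The source may hold more compounds than are shown below. What is called first, only, known or untested is meant among the compounds shown, and "the series" means these compounds.

Series notes. The shared core of compound 1 `Cc1ccc(C2(CNC(=O)Nc3c(C(C)C)cccc3C(C)C)CCCC2)cc1` carries an aryl group whose substituent is varied across the set. In an assay on microsomes for inhibition of acyl-CoA:cholesterol acyltransferase (Oryctolagus cuniculus) (a lower number here means a stronger inhibitor, a higher number a weaker inhibitor), compound 1 gives 25 nM. Compound 2 `CC(C)c1cccc(C(C)C)c1NC(=O)NCC1(c2ccc(C(C)(C)C)cc2)CCCC1` gives 63 nM in this assay, and compound 3 `CC(C)c1cccc(C(C)C)c1NC(=O)NCC1(c2ccc(Cl)cc2)CCCC1` gives 32 nM. Compound 3 stands second highest of the three numbers: it lies closest to compound 1, because a 1.3-fold higher number from compound 1 to compound 3 (0.11 log units; within the scatter), and furthest from compound 2, because a 2.0-fold lower number from compound 2 to compound 3 (0.29 log units; within the scatter). For the measured compounds named here, the only step reaching beyond the scatter is a 2.5-fold higher number from compound 1 to compound 2 (0.40 log units; beyond the scatter), and that one is modest.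

Compound 4 `COc1cccc(C2(CNC(=O)Nc3c(C(C)C)cccc3C(C)C)CCCC2)c1` has not yet been measured. Its change from compound 3: 3-methoxyphenyl in place of 4-chlorophenyl on a saturated ring carbon. Going by the values given here, every step measured so far exchanges one group on an aromatic carbon of that aryl ring, and none brings in a methoxy or any hydrogen-bond acceptor there; the steps that bear on the question are a 1.3-fold higher number from compound 1 to compound 3 (0.11 log units; within the scatter) and a 2.0-fold lower number from compound 2 to compound 3 (0.29 log units; within the scatter), both within the scatter, together with a 2.5-fold higher number from compound 1 to compound 2 (0.40 log units; beyond the scatter). On that basis no step beyond the scatter in this assay is expected for compound 4 in either direction, though the untested methoxy leaves the range wide. Compound 4 is therefore estimated at 40 nM, between 15 nM and 120 nM. The step this expectation implies is a 1.3-fold higher number from compound 3 to compound 4 (0.10 log units; within the scatter).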

Compound 4, half-maximal inhibitory concentration: 13 nM
Compound 4: middle estimate off by 3.1-fold (0.49 log units), on the high side; the measured number lies below the stated range.
By their numbers in this assay, from the lowest: compounds 4, 1, 3 and 2 (each within the scatter of the next, the first and the last beyond it).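

In this assay, 3-methoxyphenyl in place of 4-chlorophenyl on the saturated ring carbon gives a 2.5-fold lower number from compound 3 to compound 4 (0.39 log units; beyond the scatter), and in place of 4-(tert-butyl)phenyl it gives a 4.8-fold lower number from compound 2 to compound 4 (0.69 log units; beyond the scatter), so this position accepts an aryl group with a hydrogen-bond acceptor and with its substituent set as in 3-methoxyphenyl, with no loss against either of those two groups. Against 4-methylphenyl the same exchange gives a 1.9-fold lower number from compound 1 to compound 4 (0.28 log units; within the scatter), so compound 4 and compound 1 cannot be told apart, and the steps beyond the scatter hold only against compound 2 and compound 3. Nothing shown here gives a reason for these steps.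

The exchange alters the substituent and its place on the aryl ring at once, which leaves open whether the methoxy group or its place goes with the lower number, and a 4-methoxyphenyl or a 3-chlorophenyl group would separate the two. Also open, as far as these compounds go, is how this position responds to an aryl group carrying an amine, a carboxylic acid or a longer alkoxy chain.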